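The source may hold more compounds than are shown below. What is called first, only, known or untested is meant among the compounds shown, and "the series" means these compounds.

Compound 1 `COc1ccc2c(=O)c(/C=C/C(=O)Nc3cccc(Cl)c3)coc2c1` is measured in a functional assay (QGY7701 cells, Homo sapiens) for inhibition, read by MTT assay, with a stated time of 48 h; a higher number here means a weaker inhibitor, a lower number a stronger inhibitor. In this assay compound 1 returns only a limit, > 100000 nM, so its standing rests on that limit alone. Compound 2 `COc1ccc2c(=O)c(/C=C/C(=O)Nc3ccc(Cl)cc3)coc2c1` differs from compound 1 by a 4-chlorophenyl in place of a 3-chlorophenyl on an amide-type nitrogen. In this assay compound 2 likewise returns only a limit, > 100000 nM. The step between them, a step that the two limits leave unreadable from compound 1 to compound 2, therefore cannot be read in size or direction.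

Compound 3 `COc1ccc2c(=O)c(/C=C/C(=O)Nc3ccc(F)cc3)coc2c1` is not yet measured in this assay. Its change from compound 1 is 4-fluorophenyl in place of 3-chlorophenyl on an amide-type nitrogen. Among the measured compounds shown here, the only measured step, a step that the two limits leave unreadable from compound 1 to compound 2, also exchanges the group on the amide-type nitrogen and gives no readable size, so no direction can be drawn from it. The whole of the evidence on such steps is the limit of > 100000 nM in this assay, at which 2 of the 2 values shown sit. Compound 3 is expected to sit at or near that same limit, and the step that the limit leaves unreadable from compound 1 to compound 3 is estimated as nothing readable beyond the scatter. The estimate for compound 3 in this assay is 150000 nM, with a range from 30000 nM to 1000000 nM.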

Compound 3, half-maximal inhibitory concentration: > 100000 nM
Compound 3 ended at the assay's limit (the forecaster's own chance of this, stated with the estimate: 85%); the middle value lies beyond the limit too.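

In this assay compound 3 also returns only a limit, > 100000 nM, so the steps to compound 3 from compound 1 and from compound 2 cannot be read in size or direction. The compounds shown leave open whether any group on the amide-type nitrogen would give a readable value, as all three stop at one point: the limit of > 100000 nM in this assay, at which 3 of the 3 values shown sit.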